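Alkyl chain length on the shared core with a cyclic phosphate

The source may report more compounds than this note shows. Statements on the series, on what has been measured and on what is new or still open speak of the compounds shown alone.

Measured compounds:
compound 1 `CCc1cn([C@H]2C[C@@H]3OP(=O)(O)OC[C@H]3O2)c(=O)[nH]c1=O`: 60 ug/mL
compound 2 `CCCCCc1cn([C@H]2C[C@H](O)[C@@H](CO)O2)c(=O)[nH]c1=O`: 334 ug/mL
compound 3 `CCCc1cn([C@H]2C[C@H](O)[C@@H](CO)O2)c(=O)[nH]c1=O`: > 500 ug/mL

In a functional assay on Raji cells (Homo sapiens) (a lower number here means a stronger inhibitor, a higher number a weaker inhibitor), compound 1 gives 60 ug/mL, the lowest number among the compounds for which a number is given; compound 2 gives 334 ug/mL, a higher number. Compound 3 reaches only the limit (the limit of > 500 ug/mL in this assay, at which 1 of the 3 values shown sits), which is a bound of the assay and not a number.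

Compound 4 `CCCCc1cn([C@H]2C[C@@H]3OP(=O)(O)OC[C@H]3O2)c(=O)[nH]c1=O` differs from compound 1 by ethyl in place of hydrogen on a saturated chain carbon, two bonds along the chain from an aromatic carbon. Among the compounds with values here, the only measured step on chain length is the one from compound 2 to compound 3, where the shorter chain gave an at least 1.4-fold higher number from compound 2 to compound 3 (0.17 log units; that floor lies within the scatter); that step touches the scatter and comes from compounds lacking the cyclic phosphate, so it is weak support. For compound 4 the expectation is therefore no change beyond the scatter, with at most a small drift toward a lower number, a 1.2-fold lower number from compound 1 to compound 4 (0.08 log units; within the scatter). Compound 4 is estimated at 50 ug/mL, within 15 ug/mL to 160 ug/mL.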

Compound 4, concentration for 50% inhibition: 82 ug/mL
Compound 4: the middle estimate sits 1.6-fold (0.21 log units) below what was measured; the measured number falls inside the stated range.
By their numbers in this assay, from the lowest: compounds 1 and 4 (each within the scatter of the next); then compound 2. At a limit, above all of these: compound 3.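

In this assay, ethyl in place of hydrogen on a saturated chain carbon, two bonds along the chain from an aromatic carbon, gives a 1.4-fold higher number from compound 1 to compound 4 (0.14 log units; within the scatter), so ethyl and butyl cannot be told apart on the core of compound 1. Within the data shown here, this is the first chain step with a number at both ends, as the earlier step ends in compound 3, whose value is a limit. Whether the chain behaves alike on the two cores remains unresolved: the same change on two cores in this assay, an at least 1.4-fold higher number (0.17 log units; that floor lies within the scatter) from compound 2 to compound 3 and a 1.4-fold lower number (0.14 log units; within the scatter) from compound 4 to compound 1; the limit leaves it open whether they differ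

Still open, on these data alone, is whether a longer chain such as octyl, or a butyl chain ending in an amine or a carboxylic acid, would move the number on the core of compound 1 beyond the scatter. The contribution of the cyclic phosphate at a fixed chain also stays open, with no pair shown differing in that place alone.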